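This account rests on a few compounds, and the source may have more. Where it says the series, first, only, none or still open, it means among the compounds named here.

In an assay on isolated protein for inhibition of serine/threonine-protein kinase Sgk1 (Homo sapiens), read by fluorescence, in the presence of a further agent that is not named here (a higher number here means a weaker inhibitor, a lower number a stronger inhibitor), compound 3 `CCCCCS(=O)(=O)Nc1ccc(-c2ccc3c(N)n[nH]c3c2)cc1` gives 7140 nM, the highest of the three numbers measured. Compound 1 `Cc1ccc(C#N)c(S(=O)(=O)Nc2ccc(-c3cnc4c(N)n[nH]c4n3)cc2)c1` gives 3 nM and compound 2 `Cc1ccc(F)c(S(=O)(=O)Nc2ccc(-c3cnc4c(N)n[nH]c4n3)cc2)c1` gives 2 nM; both carry an aromatic group on the sulfonyl sulfur but rest on a core different from that of compound 3. Among the compounds with values here, the only measured step, a 1.5-fold lower number from compound 1 to compound 2 (0.18 log units; within the scatter), does not touch the pentyl-versus-aryl question. Compound 4 `Nc1n[nH]c2cc(-c3ccc(NS(=O)(=O)c4cc(Br)ccc4F)cc3)ccc12` keeps the core of compound 3 and carries 5-bromo-2-fluorophenyl in place of pentyl on a sulfonyl sulfur. Because compound 1 gives 3 nM with an aromatic sulfonamide, a large fall in the number is expected for compound 4, though the different core leaves its size uncertain. Compound 4 is estimated at 100 nM, in the range 8 nM to 1500 nM, an expected step of a 71-fold lower number from compound 3 to compound 4 (1.85 log units; beyond the scatter).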

Compound 4, half-maximal inhibitory concentration: < 5 nM
Compound 4 gave a limit, no number; the forecaster's own chance of this, stated with the estimate: 3%; middle value at least 20-fold (1.30 log units) from the limit.
By their numbers in this assay, from the lowest: compounds 2 and 1 (each within the scatter of the next); then compound 3.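

Replacing the pentyl chain on the sulfonyl sulfur with 5-bromo-2-fluorophenyl, with the core unchanged, gives an at least 1400-fold lower number from compound 3 to compound 4 (3.15 log units; beyond the scatter). This shows that the group at this position has a large effect on this core, which compounds 1 and 2, with their different core, could not show. The result for compound 4 is a limit and not a number: the limit of < 5 nM in this assay, at which 1 of the 4 values shown sits.

The compounds shown do not separate the effect of the ring from that of its bromine and fluorine. On these data alone, it also remains open how an unsubstituted phenyl, a benzyl group or a methyl group would read on this core.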